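The source may hold more compounds than are shown below. What is called first, only, known or untested is meant among the compounds shown, and "the series" means these compounds.

Working notes on the pyridyl amidrazone thiosemicarbazide series. Two compounds have been run in a functional assay on HeLa cells (Homo sapiens) for cytotoxicity, read by MTT assay, with a stated time of 72 h, tested at 10 uM; on this read-out lower numbers stand for less inhibition of growth and higher numbers for more inhibition of growth at the one concentration tested. Compound 1 `Cc1ccnc(/C(N)=N/NC(=S)N2CCSCC2)c1` gives 39.2% in this assay. For the measured compounds named here, compound 2 `N/C(=N\NC(=S)N1CCCC1)c1ccccn1` gives 63.5% in this assay and thus holds the higher of the two numbers, with the gap to compound 1 beyond the scatter; the two differ in more than one place, so no single step is read from them. Compound 3 `Cc1ccnc(/C(N)=N/NC(=S)N2CCCC2)c1` has not yet been measured. Relative to compound 2 the change is methyl in place of hydrogen on an aromatic carbon. Going by the values given here, no step between measured compounds isolates this change. Compound 1, which carries the same methyl on its core but differs in a second place as well, sits at 39.2%, so a downward step of moderate size is expected, though the second difference leaves this uncertain. Compound 3 is expected near 50%, with a range from 30% to 70%. This estimate implies an expected step of a number 13.5 percentage points lower from compound 2 to compound 3 (beyond the scatter).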

Compound 3, percent growth inhibition at one concentration: 67%
Estimate against measurement, compound 3: 17 percentage points below, within the range that was stated.
By their numbers in this assay, from the lowest: compound 1; then compounds 2 and 3 (each within the scatter of the next).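

In this assay, methyl in place of hydrogen on an aromatic carbon, opposite the ring nitrogen, gives a number 3.5 percentage points higher from compound 2 to compound 3 (within the scatter), so in this pyrrolidin-1-yl pair the methyl and the hydrogen cannot be told apart. With the methyl common to both compounds, pyrrolidin-1-yl in place of thiomorpholin-4-yl on a thiocarbonyl carbon gives a number 27.8 percentage points higher from compound 1 to compound 3 (beyond the scatter), which places the gap in this pair at the thiocarbonyl substituent and shows that the methyl does not by itself bring the number down to that of compound 1. No measurement at hand bears on the reason for either step.

As far as these compounds go, whether a longer alkyl chain, a methoxy group or an amine on that aromatic carbon would also stay within the scatter of compound 2 remains open. Also open, from the compounds shown here alone, is whether the methyl step would read the same with thiomorpholin-4-yl on the thiocarbonyl carbon.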